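Ring-nitrogen substituent on the shared core: isopropyl step

This account rests on a few compounds, and the source may have more. Where it says the series, first, only, none or still open, it means among the compounds named here.

Notes on the series. Compound 3 `COc1ncc(-c2ccc3c(c2)NC(=O)CO3)cc1NS(=O)(=O)c1ccc(F)cc1` carries a hydrogen on the amide-type nitrogen in the ring of the shared core. In a functional assay on HCT-116 cells (Homo sapiens) for antiproliferative activity, read by MTT assay, with a stated time of 72 h (a higher number here means a weaker inhibitor, a lower number a stronger inhibitor), compound 3 gives 24900 nM. Compound 2 `CC(C)N1C(=O)COc2ccc(-c3cnc(Cl)c(NS(=O)(=O)c4ccc(F)cc4)c3)cc21`, which bears an isopropyl on that nitrogen but differs elsewhere too, gives 18900 nM in this assay; the two values lie within the scatter of one another, so neither is set apart. Compound 1 `COc1ncc(-c2ccc3c(c2)N(c2ccc(F)cc2)C(=O)CO3)cc1NS(=O)(=O)c1ccc(F)cc1` reaches only a limit of this assay, > 40000 nM. For the measured compounds named here, the single measured step at this nitrogen is an at least 1.6-fold lower number from compound 1 to compound 3 (0.20 log units; that floor lies within the scatter), and it rests on (the limit of > 40000 nM in this assay, at which 1 of the 3 values shown sits), so its floor tells little beyond the scatter.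

Compound 4 `COc1ncc(-c2ccc3c(c2)N(C(C)C)C(=O)CO3)cc1NS(=O)(=O)c1ccc(F)cc1` differs from compound 3 by isopropyl in place of hydrogen on an amide-type nitrogen in a ring. Going by the values given here, no measured step at this position is beyond the scatter, and compound 2 with the same isopropyl sits close to compound 3, so no shift beyond the scatter is expected. The step is estimated as a 1.2-fold lower number from compound 3 to compound 4 (0.10 log units; within the scatter). Compound 4 is therefore expected to give about 20000 nM in this assay, within 8000 nM to 50000 nM.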

Compound 4, half-maximal inhibitory concentration: 19200 nM
For compound 4 the middle estimate is 1.0-fold (0.02 log units) above the measured one; low and high end bracket the measured number.
By their numbers in this assay, from the lowest: compounds 2, 4 and 3 (each within the scatter of the next). At a limit, above all of these: compound 1.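

With the rest of the shared core held constant, isopropyl on the amide-type nitrogen now has a direct reading in this assay: a 1.3-fold lower number from compound 3 to compound 4 (0.11 log units; within the scatter), so hydrogen and isopropyl are not set apart at this position. With the isopropyl held, methoxy in place of chloro on an aromatic carbon can also be read alone, and it gives a 1.0-fold higher number from compound 2 to compound 4 (0.01 log units; within the scatter), so these two groups are not set apart either. For the compounds shown here, the only step beyond the scatter is an at least 2.0-fold lower number from compound 1 to compound 4 (0.31 log units; beyond the scatter), and compound 1 enters it only as a limit, so its size is a floor: the limit of > 40000 nM in this assay, at which 1 of the 4 values shown sits.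

Open, as far as these compounds go, is whether another group on this nitrogen, such as a longer chain, an amine-bearing chain or a carboxylic acid-bearing chain, would move the number beyond the scatter. Also open, from the compounds shown here alone, is how far 4-fluorophenyl and isopropyl truly lie apart on this nitrogen.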